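Benzyl variation on the isatin-like core and a ring substituent change

The compounds below may be only part of what the source reports. "The series", "measured", "known", "first", "only" and "open" are said of these compounds alone.

Compound 1 `COC(=O)/C=C/c1ccc2c(c1)C(=O)C(=O)N2Cc1ccc(C)cc1` gives 30 nM in a functional assay on HT-29 cells (Homo sapiens) for cytotoxicity, read by MTT assay, with a stated time of 48 h (on this read-out lower numbers stand for stronger inhibition and higher numbers for weaker inhibition), the lowest number of the three measured. Compound 2 `COC(=O)/C=C/c1ccc2c(c1)C(=O)C(=O)N2Cc1ccc(Cl)c(Cl)c1` gives 210 nM and compound 3 `CCN1C(=O)C(=O)c2cc(/C=C/C(=O)OC)ccc21` gives 210 nM. The measured steps are a 7.0-fold higher number from compound 1 to compound 2 (0.85 log units; beyond the scatter), a 7.0-fold higher number from compound 1 to compound 3 (0.85 log units; beyond the scatter) and no change at the digits printed from compound 2 to compound 3 (within the scatter); all three swap the whole group on the saturated chain carbon bound to the amide-type nitrogen in a ring. Compound 4 `COC(=O)/C=C/c1ccc2c(c1)C(=O)C(=O)N2Cc1ccc(C(F)(F)F)cc1` differs from compound 1 elsewhere: trifluoromethyl in place of methyl on an aromatic carbon. Going by the values given here, no measured step touches that aromatic carbon, so the direct evidence is thin; the 4-methylphenyl pattern is kept, which argues for at most a modest change. Compound 4 is expected to give 50 nM (range 15 nM to 160 nM), meaning an expected step of a 1.7-fold higher number from compound 1 to compound 4 (0.22 log units; within the scatter).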

Compound 4, half-maximal inhibitory concentration: 40 nM
Compound 4: middle estimate off by 1.3-fold (0.10 log units), on the high side; the range from low to high includes it.
By their numbers in this assay, from the lowest: compounds 1 and 4 (each within the scatter of the next); then compounds 2 and 3 (each within the scatter of the next).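

In this assay, trifluoromethyl in place of methyl on the aromatic carbon para to a large group reads as a 1.3-fold higher number from compound 1 to compound 4 (0.12 log units; within the scatter) and so stays within the scatter. Going by these compounds alone, this aromatic carbon therefore accepts a swap of one heavy atom for four without a step beyond the scatter, whereas the earlier steps showed only changes of the whole group on the saturated chain carbon. Nothing available bears on the reason for this result.

On these data alone, whether this holds for an amine, a carboxylic acid or a longer chain on the same aromatic carbon stays open.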